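The source may report more compounds than this note shows. Statements on the series, on what has been measured and on what is new or still open speak of the compounds shown alone.

Compound 1 `CCNC(=O)Nc1cccc2c1CN(C)CC2c1ccccc1` — 54 mg/kg
Compound 2 `CCCCNC(=O)Nc1cccc2c1CN(C)CC2c1ccc(C)cc1` — about 15 mg/kg
Compound 3 `CCOC(=O)Nc1cccc2c1CN(C)CC2c1ccc(Cl)cc1` — 0.6 mg/kg

Of the compounds shown here, three sharing one core have been measured in a functional assay on the whole organism for inhibition, with Mus musculus as the target; on this read-out lower numbers stand for an effect already at smaller amounts and higher numbers for an effect only at larger amounts of compound. Compound 1 gives 54 mg/kg, the highest number of the three. Compound 2 gives about 15 mg/kg, a lower number than compound 1 by a margin beyond the usual scatter, and compound 3 gives 0.6 mg/kg, lower still and far beyond the scatter. Compound 2 and compound 3 each differ from compound 1 in more than one place, so neither gap can be tied to a single structural change.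

The unmeasured compound 4 `CN1Cc2c(NC(=O)CN3CCCC3)cccc2C(c2ccccc2)C1` differs from compound 1 in one place only: (pyrrolidin-1-yl)methyl in place of ethylamino on a carbonyl carbon Cut one bond further out, the change reads ethylcarbamoyl to ((pyrrolidin-1-yl)methyl)carbonyl. Going by the values given here, no measured pair isolates this change, so nothing in the data fixes its direction or size. Since compound 1 holds the highest number of the set, a moderate step downward is expected for compound 4, about a 2.7-fold lower number from compound 1 to compound 4 (0.43 log units; beyond the scatter), though the uncertainty is wide. The estimate for compound 4 in this assay is 20 mg/kg, expected to fall between 4 mg/kg and 100 mg/kg.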

Compound 4, dose for half-maximal effect: about 25 mg/kg
Compound 4: the middle estimate sits 1.3-fold (0.10 log units) below what was measured, within the range that was stated.
By their numbers in this assay, from the lowest: compound 3; then compounds 2 and 4 (each within the scatter of the next); then compound 1.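

In this assay, going by these compounds alone, (pyrrolidin-1-yl)methyl in place of ethylamino on a carbonyl carbon gives a 2.2-fold lower number from compound 1 to compound 4 (0.33 log units; beyond the scatter), and this is the first step in the set that can be tied to one place. It shows that this place accepts a larger group carrying a five-membered non-aromatic ring, and that the effect survives the loss of the ethylamino group with its hydrogen-bond donor. Because the size, the ring and the donor and acceptor counts all change together, this single step does not separate their contributions, and no measured property at hand bears on it.

Still open, as far as these compounds go, is whether the much lower number of compound 3, 0.6 mg/kg, belongs to the ethoxy group on the carbonyl carbon or to its other difference from compound 1. Equally open, from the compounds shown here alone, is how the number would respond if the pyrrolidine ring of compound 4 gave way to a piperidine ring or an open dimethylamino group on the same methyl.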